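Changing the ring on the triazole nitrogen once more

The source may hold more compounds than are shown below. What is called first, only, known or untested is meant among the compounds shown, and "the series" means these compounds.

The three measured compounds share one core and were tested in a functional assay on PANC-1 cells (Homo sapiens) for inhibition, read by MTT assay, with a stated time of 24 h; a higher number here means a weaker inhibitor, a lower number a stronger inhibitor:
Compound 1 `CC1(C)[C@H]2CC[C@]1(C)N(Cc1cn(-c3ccccc3)nn1)C(=O)C2`: 160 nM
Compound 2 `CC1(C)[C@H]2CC[C@]1(C)N(Cc1cn(-c3ccccc3C#N)nn1)C(=O)C2`: 240 nM
Compound 3 `CC1(C)[C@H]2CC[C@]1(C)N(Cc1cn(-c3ccc(F)cc3)nn1)C(=O)C2`: 110 nM

Compound 3 has the lowest of the three numbers. Its nearest neighbour is compound 1, and the step of a 1.5-fold lower number from compound 1 to compound 3 (0.16 log units; within the scatter) is within the scatter; the step of a 2.2-fold lower number from compound 2 to compound 3 (0.34 log units; beyond the scatter) is the only one beyond it, and even that is modest.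

Compound 4 `COc1cccc(-n2cc(CN3C(=O)C[C@@H]4CC[C@@]3(C)C4(C)C)nn2)c1` differs from compound 3 in one place: 3-methoxyphenyl in place of 4-fluorophenyl on an aromatic nitrogen.

All three measured steps change the same ring on the aromatic nitrogen, so all bear on this one. The step of a 1.5-fold higher number from compound 1 to compound 2 (0.18 log units; within the scatter) and the step of a 1.5-fold lower number from compound 1 to compound 3 (0.16 log units; within the scatter) both fall within the scatter, and the step of a 2.2-fold lower number from compound 2 to compound 3 (0.34 log units; beyond the scatter) is only modest. The ring on the aromatic nitrogen has therefore so far moved the number in this assay little in either direction. A new substitution pattern with one hydrogen-bond acceptor entering has no measured counterpart among these compounds, so the step for compound 4 is expected to be small, most likely within the scatter, in no fixed direction.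

Compound 4 is therefore estimated at 160 nM in this assay, with a range from 70 nM to 360 nM, which means an expected step of a 1.5-fold higher number from compound 3 to compound 4 (0.16 log units; within the scatter).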

Compound 4, half-maximal inhibitory concentration: 860 nM
Estimate against measurement, compound 4: 5.4-fold (0.73 log units) below; measured number above the stated range.
By their numbers in this assay, from the lowest: compounds 3, 1 and 2 (each within the scatter of the next, the first and the last beyond it); then compound 4.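

In this assay this position turns out not to be indifferent to the ring it carries: adding methoxy gives a 5.4-fold higher number from compound 1 to compound 4 (0.73 log units; beyond the scatter) and lies beyond the scatter, whereas the cyano and fluoro changes made on compound 1 stayed within it. The other two comparisons agree, with a 7.8-fold higher number from compound 3 to compound 4 (0.89 log units; beyond the scatter) and a 3.6-fold higher number from compound 2 to compound 4 (0.55 log units; beyond the scatter) both also beyond the scatter, so the largest gaps in this small set are now those leading to compound 4 and not those among the three earlier compounds. Nothing given here explains why the number rises with 3-methoxyphenyl on the aromatic nitrogen.

The compounds shown leave open whether the rise belongs to the methoxy group itself or to its place on the phenyl ring, a question that a methoxy group elsewhere on that ring could help settle. Also open, from the compounds shown here alone, is how a hydroxyl, an amine or a longer ether chain would behave in place of methoxy, and whether any of them would keep the number close to those of compound 1 and compound 3.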